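Fluorine on the phenyl ring and microsomal stability

The source may report more compounds than this note shows. Statements on the series, on what has been measured and on what is new or still open speak of the compounds shown alone.

Measured so far:
- compound 1 `Cc1cc(F)cc(-c2c([C@H](C)Nc3nc(N)nc(N)c3C#N)cc3ccc(F)cn3c2=O)c1`: 80%
- compound 2 `C[C@H](Nc1nc(N)nc(N)c1C#N)c1cc(=O)n2cc(F)ccc2c1-c1ccccc1`: "not determined" (no result reported)
- compound 3 `C[C@H](Nc1ncnc(N)c1C#N)c1cc(=O)n2cc(F)ccc2c1-c1ccccc1`: 90%

Three compounds share the same core, and two of them have a number in an ADME assay on microsomes from liver (Homo sapiens), read by LC-MS, using NADPH, with a stated time of 30 min, tested at 1 uM; a higher number here means that more of the compound is left, a lower number that less of the compound is left. Compound 3 gives 90% in this assay, the higher of the two numbers. Its nearest neighbour is compound 1, which gives 80% in this assay, a gap that lies within the scatter of the measurement, so the two cannot be told apart. For compound 2 this assay reports "not determined" (no result reported), so it adds nothing to the comparison.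

Compound 4 `C[C@H](Nc1ncnc(N)c1C#N)c1cc(=O)n2cc(F)ccc2c1-c1cccc(F)c1` is not yet measured. It differs from compound 3 in one place: fluoro in place of hydrogen on an aromatic carbon, meta to a large group, so that the phenyl becomes a 3-fluorophenyl. For the measured compounds named here, no measured pair shows such a step, so the expectation rests on the high standing of compound 3 alone. The change is small, and the step from compound 3 to compound 4 is expected to stay within the scatter, a number 5 percentage points lower from compound 3 to compound 4 (within the scatter). Compound 4 is therefore estimated at 85% in this assay, with a range from 65% to 98%.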

Compound 4, percent of the compound remaining: 87%
Beside the measured number, compound 4's estimate is 2 percentage points below it; measured number inside the range.
By their numbers in this assay, from the lowest: compounds 1, 4 and 3 (each within the scatter of the next).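

In this assay, for the compounds shown here, the phenyl to 3-fluorophenyl change gives the first step in this set between two compounds that differ in one place, a number 3 percentage points lower from compound 3 to compound 4 (within the scatter), and the two cannot be told apart. This shows that, in this pair on the shared core, the aromatic carbon meta to a large group can carry fluoro in place of hydrogen with no difference beyond the scatter. No measurement shown here accounts for this result.

The compounds shown leave open whether a methoxy group, a trifluoromethyl group or an amine at the same place would also stay within the scatter of compound 3. They also leave open how fluoro would read on the other carbons of the phenyl ring.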